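From 4-methylphenyl to 3-methylphenyl: a small step expected

A few compounds are considered here, and "the series" means these few. Any claim that something is new, unique, unknown or untested is made for them only; others in the source may bear on it.

Three compounds with a shared core have numbers in an ADME assay on L02 cells (Homo sapiens) for inhibition, read by CCK-8 assay, with a stated time of 48 h (on this read-out lower numbers stand for stronger inhibition of growth and higher numbers for weaker inhibition of growth), so far. Compound 1 `CN1CCN(c2ccc(Nc3ncc(Cl)c(Nc4ccccc4)n3)nc2)CC1` gives 7990 nM there, compound 2 `CN1CCN(c2ccc(Nc3ncc(Cl)c(NCc4ccc(F)cc4)n3)nc2)CC1` gives 39700 nM there and compound 3 `Cc1ccc(Nc2nc(Nc3ccc(N4CCN(C)CC4)cn3)ncc2Cl)cc1` gives 13900 nM there. Compound 3 thus lies within the scatter of compound 1 and lower than compound 2 by more than the scatter. Compound 4 `Cc1cccc(Nc2nc(Nc3ccc(N4CCN(C)CC4)cn3)ncc2Cl)c1` has 3-methylphenyl in place of 4-methylphenyl on a nitrogen on an aromatic ring. Among the compounds with values here, no measured step shows this exchange directly. The nearest evidence is methyl in place of hydrogen on an aromatic carbon, which gave a 1.7-fold higher number from compound 1 to compound 3 (0.24 log units; within the scatter) and stayed within the scatter. The steps of a 5.0-fold higher number from compound 1 to compound 2 (0.70 log units; beyond the scatter) and a 2.9-fold lower number from compound 2 to compound 3 (0.46 log units; beyond the scatter) were modest, but both involve 4-fluorobenzyl, a group that neither compound 3 nor compound 4 carries. No change beyond the scatter is therefore expected in this assay, and the expected step is a 1.2-fold lower number from compound 3 to compound 4 (0.06 log units; within the scatter) at most in size. For compound 4 the estimate is 12000 nM with an expected range of 6000 nM to 25000 nM in repeated measurements.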

Compound 4, concentration for 50% growth inhibition: 6080 nM
For compound 4 the middle estimate is 2.0-fold (0.30 log units) above the measured one; the range from low to high includes it.
By their numbers in this assay, from the lowest: compounds 4, 1 and 3 (each within the scatter of the next, the first and the last beyond it); then compound 2.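

In this assay, within the data shown here, shifting the methyl within the aryl group on the nitrogen, with the same atoms joined differently, gave a 2.3-fold lower number from compound 3 to compound 4 (0.36 log units; beyond the scatter) and so showed that this position responds to where the methyl stands, which the earlier compounds could not show. Methyl in place of hydrogen on an aromatic carbon gave a 1.3-fold lower number from compound 1 to compound 4 (0.12 log units; within the scatter) as the 3-methylphenyl compound, so compound 1 and compound 4 cannot be told apart here. Replacing 4-fluorobenzyl with 3-methylphenyl gave a 6.5-fold lower number from compound 2 to compound 4 (0.81 log units; beyond the scatter) in this assay, a step that also stands beyond the scatter.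

On these data alone, whether a methoxy group, a chlorine or an amine in place of the methyl on the 3-methylphenyl would give a similar number stays open. Nothing available here accounts for the difference between the two methylphenyl compounds.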